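Swapping 3-Chlorophenyl for 4-Fluorophenyl on the Amide Nitrogen

The source may report more compounds than this note shows. Statements on the series, on what has been measured and on what is new or still open speak of the compounds shown alone.

Compound 1 `COc1ccc2c(=O)c(/C=C/C(=O)Nc3cccc(Cl)c3)coc2c1`: 1100000 nM
Compound 2 `COc1ccc2c(=O)c(/C=C/C(=O)Nc3ccccc3Cl)coc2c1`: 1010000 nM
Compound 3 `COc1ccc2c(=O)c(/C=C/C(=O)Nc3ccc(Cl)cc3)coc2c1`: 272000 nM

All three were tested in an ADME assay on HepG2 2.2.15 cells (Homo sapiens) for cytotoxicity, read by MTT assay, with stated times of 48 h and 9 days; on this read-out lower numbers stand for higher toxicity in this test and higher numbers for lower toxicity in this test. Compound 1 gives the highest number of the three; compound 2 lies within the scatter of it, with a 1.1-fold lower number from compound 1 to compound 2 (0.04 log units; within the scatter), whereas compound 3 stands further off, with a 4.0-fold lower number from compound 1 to compound 3 (0.61 log units; beyond the scatter) and a 3.7-fold lower number from compound 2 to compound 3 (0.57 log units; beyond the scatter). Compound 4 `COc1ccc2c(=O)c(/C=C/C(=O)Nc3ccc(F)cc3)coc2c1` has not yet been measured. It differs from compound 1 in one place: 4-fluorophenyl in place of 3-chlorophenyl on an amide-type nitrogen. Among the measured compounds shown here, no measured step exchanges chlorine for fluorine, so the only step that bears on this change is the one replacing 3-chlorophenyl with 4-chlorophenyl, a 4.0-fold lower number from compound 1 to compound 3 (0.61 log units; beyond the scatter), which was modest and lowered the number. Compound 4 is therefore expected to show a 1.8-fold lower number from compound 1 to compound 4 (0.26 log units; within the scatter), a smaller shift than that seen with compound 3. The estimate for compound 4 is 600000 nM, with a range from 250000 nM to 1400000 nM.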

Compound 4, half-maximal cytotoxic concentration: 743000 nM
For compound 4 the middle estimate is 1.2-fold (0.09 log units) below the measured one; low and high end bracket the measured number.
By their numbers in this assay, from the lowest: compound 3; then compounds 4, 2 and 1 (each within the scatter of the next).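

In this assay, the direct exchange of fluoro for chloro on the aromatic carbon gives a 2.7-fold higher number from compound 3 to compound 4 (0.44 log units; beyond the scatter), so the lower number of compound 3 is not shared by 4-fluorophenyl. The other two steps stay inside the usual scatter, with a 1.5-fold lower number from compound 1 to compound 4 (0.17 log units; within the scatter) and a 1.4-fold lower number from compound 2 to compound 4 (0.13 log units; within the scatter), which leaves compound 3 alone apart from the other three compounds. No measurement shown here accounts for this difference between the two halogens.

As far as these compounds go, whether an amine or a carboxylic acid on the phenyl ring, in place of the halogen, would keep the number at this level remains open.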